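A few compounds are considered here, and "the series" means these few. Any claim that something is new, unique, unknown or untested is made for them only; others in the source may bear on it.

Measured in a functional assay (Homo sapiens) for antiproliferative activity; on this read-out higher numbers stand for weaker inhibition of growth and lower numbers for stronger inhibition of growth:
- Compound 1 `Cc1sc2nc(-c3ccncc3)c(/C=N/NC(=N)N)n2c1C`: 91200 nM
- Compound 2 `Cc1sc2nc(-c3ccccn3)c(/C=N/NC(=N)N)n2c1C`: 41700 nM
- Compound 3 `N=C(N)N/N=C/c1c(-c2ccccn2)nc2sc(Cl)cn12`: 20900 nM

Compound 3 lies within the usual scatter of compound 2 and clearly lower than compound 1, so it sits among the stronger growth inhibitors of this small set. Compound 4 `N=C(N)N/N=C/c1c(-c2ccncc2)nc2sc(Cl)cn12` has the same atoms joined differently, with pyridin-4-yl in place of pyridin-2-yl on an aromatic carbon.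

Among the compounds with values here, only one measured step bears on this: the same exchange, run the opposite way on a related core, a 2.2-fold lower number from compound 1 to compound 2 (0.34 log units; beyond the scatter). A single pair is thin evidence, but a modest rise is expected on reversing it. The expected change in this assay is a 2.2-fold higher number from compound 3 to compound 4 (0.33 log units; beyond the scatter). For compound 4 the estimated value is 45000 nM, with an expected range from 22000 nM to 90000 nM.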

Compound 4, concentration for total growth inhibition: 40700 nM
The estimate for compound 4 lay 1.1-fold (0.04 log units) above the measured number, and the stated range covers the measured number.
By their numbers in this assay, from the lowest: compounds 3, 4 and 2 (each within the scatter of the next); then compound 1.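

In this assay, pyridin-4-yl in place of pyridin-2-yl on the core of compound 3 gives a 1.9-fold higher number from compound 3 to compound 4 (0.29 log units; within the scatter), a step too small to count as a real difference by itself. Even so, the exchange at this position now reads alike on two cores, so the earlier single pair no longer stands alone: the same change on two cores in this assay, a 2.2-fold lower number (0.34 log units; beyond the scatter) from compound 1 to compound 2 and a 1.9-fold lower number (0.29 log units; within the scatter) from compound 4 to compound 3, 1.1-fold (0.05 log units) apart, within the scatter of two such steps

The compounds shown leave open how pyridin-3-yl or a plain phenyl ring would read at this position. They therefore cannot tell whether a ring nitrogen is needed there at all.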